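Trimming the side chain of compound 3 to a vinyl group

This account rests on a few compounds, and the source may have more. Where it says the series, first, only, none or still open, it means among the compounds named here.

Measured compounds:
- compound 1, `COc1ccc(/C=C/C[C@H]2C[C@H]([C@H](O)c3ccc(OC)c(OC)c3)CO[C@@H]2c2ccc(OC)c(OC)c2)cc1OC`: 23500 nM
- compound 2, `Oc1ccccc1/C=C/C[C@H]1C[C@@H]([C@@H](O)c2ccccc2)CO[C@@H]1c1ccccc1`: 10800 nM
- compound 3, `Oc1ccc(/C=C/C[C@H]2C[C@@H]([C@@H](O)c3ccccc3)CO[C@@H]2c2ccccc2)cc1`: 7380 nM

All three were tested in a functional assay on HL-60 cells (Homo sapiens) for cytotoxicity, read by WST assay, with a stated time of 48 h; on this read-out higher numbers stand for weaker inhibition and lower numbers for stronger inhibition. Compound 3 stands at the lowest number of the three. Its neighbour is compound 2, and the step of a 1.5-fold lower number from compound 2 to compound 3 (0.17 log units; within the scatter) separates them; compound 1 sits further away from compound 3, with a gap beyond the scatter.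

Compound 4, `C=CC[C@H]1C[C@@H]([C@@H](O)c2ccccc2)CO[C@@H]1c1ccccc1`, is not yet measured. It differs from compound 3 in one place: vinyl in place of 2-(4-hydroxyphenyl)ethenyl on a saturated chain carbon bound to a saturated ring carbon. A hydroxyl-bearing aromatic ring and the chain carbons that carry it are thus cut away, and only the vinyl group remains on the saturated chain carbon bound to the saturated ring carbon.

Among the measured compounds shown here, no measured step bears directly on this change. For the measured compounds named here, the only step at hand, a 1.5-fold lower number from compound 2 to compound 3 (0.17 log units; within the scatter), moves a hydroxyl around the same aromatic ring and changes little, so it tells nothing about losing that ring altogether. The comparison of compound 1 with compound 3 concerns methoxy groups on several rings and is also not the same change. With the removal of a whole aromatic ring and its hydroxyl, a weakening seems the more likely outcome, estimated as a 2.7-fold higher number from compound 3 to compound 4 (0.43 log units; beyond the scatter). Compound 4 is therefore expected to give about 20000 nM, in the range 7000 nM to 60000 nM.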

Compound 4, half-maximal inhibitory concentration: 36000 nM
Estimate against measurement, compound 4: 1.8-fold (0.26 log units) below; low and high end bracket the measured number.
By their numbers in this assay, from the lowest: compounds 3 and 2 (each within the scatter of the next); then compounds 1 and 4 (each within the scatter of the next).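

In this assay, cutting the 2-(4-hydroxyphenyl)ethenyl group back to vinyl on a saturated chain carbon bound to a saturated ring carbon gives a 4.9-fold higher number from compound 3 to compound 4 (0.69 log units; beyond the scatter), and the same cut from the 2-(2-hydroxyphenyl)ethenyl group gives a 3.3-fold higher number from compound 2 to compound 4 (0.52 log units; beyond the scatter); both steps lie beyond the scatter. Until now this position had shown only a 1.5-fold lower number from compound 2 to compound 3 (0.17 log units; within the scatter), so it was unclear whether the group there mattered at all, whereas these two steps show that keeping a hydroxyphenyl-bearing group counts for more here than which of the two hydroxyphenyl groups is present. Nothing available explains why the number rises when this group is shortened.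

Going by these compounds, the ring and its hydroxyl leave together in these steps, so their separate shares remain unknown; a 2-phenylethenyl group, which keeps the ring without the hydroxyl, would begin to separate them. Also open, on these data alone, is how this position would respond to a different kind of group, such as a longer saturated alkyl chain, an amine or a carboxylic acid.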